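The compounds below may be only part of what the source reports. "The series", "measured", "known", "first", "only" and "open" are said of these compounds alone.

Measured so far:
compound 1 `O=C(O)c1cccc(Cc2c(-c3cccc(Cl)c3)nn3cc(Cl)ccc23)n1`, in a functional assay on cells for antagonist activity at prostaglandin E2 receptor EP1 subtype (Rattus norvegicus), read by fluorescence and calcium flux, with a stated time of 60 s (a lower number here means a stronger inhibitor, a higher number a weaker inhibitor), compound 1 gives 480 nM
compound 2 `O=C(O)c1cccc(Cc2c(-c3ccc(Cl)cc3)nn3cc(Cl)ccc23)n1`, compound 2 gives 1100 nM
compound 3 `O=C(O)c1cccc(Cc2c(-c3cccs3)nn3cc(Cl)ccc23)n1`, compound 3 gives 1100 nM

Compound 3 stands level with compound 2, the two together at the highest numbers of the three, and a 2.3-fold higher number from compound 1 to compound 3 (0.36 log units; beyond the scatter) separates it from compound 1. Compound 4 `O=C(O)c1cccc(Cc2c(-c3ccsc3)nn3cc(Cl)ccc23)n1` differs from compound 3 by thiophen-3-yl in place of thiophen-2-yl on an aromatic carbon. Among the measured compounds shown here, the steps that bear on this change are those that swap the aryl group at the same carbon: a 2.3-fold higher number from compound 1 to compound 3 (0.36 log units; beyond the scatter) and no change at the digits printed from compound 2 to compound 3 (within the scatter). None of them exchanges one thiophene attachment for the other, so the expectation rests on the modest size of all swaps seen at this position. The expected step is no change at the digits printed from compound 3 to compound 4 (within the scatter), within the scatter. Compound 4 is therefore estimated at 1100 nM, with a range from 400 nM to 3000 nM.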

Compound 4, half-maximal inhibitory concentration: 110 nM
The estimate for compound 4 lay 10-fold (1.00 log units) above the measured number, outside the stated range (below it).
By their numbers in this assay, from the lowest: compound 4; then compound 1; then compounds 2 and 3 (each within the scatter of the next).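

In this assay, the point of attachment of the thiophene proves to matter at this position: the same atoms, joined differently, give a 10-fold lower number from compound 3 to compound 4 (1.00 log units; beyond the scatter), a larger step than any earlier swap here. Thiophen-3-yl also compares well with both chlorophenyl groups, giving a 10-fold lower number from compound 2 to compound 4 (1.00 log units; beyond the scatter) and a 4.4-fold lower number from compound 1 to compound 4 (0.64 log units; beyond the scatter), so compound 4 has the lowest number of the four. No supporting data are available to explain this difference.

On these data alone, it remains open whether a furyl or pyridyl group at this carbon would behave like thiophen-3-yl. Also open, as far as these compounds go, is whether the step would persist with a fluorine in place of the chlorine on the shared core.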